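The source may report more compounds than this note shows. Statements on the series, on what has been measured and on what is new or still open speak of the compounds shown alone.

Measured so far in a functional assay on CHO cells for agonist activity at adenosine receptor A1 (Homo sapiens), read by fluorescence and ERK phosphorylation, with stated times of 30 min and 1.5 h, tested at 3 uM; on this read-out higher numbers stand for a stronger effect at the one concentration tested and lower numbers for a weaker effect:
compound 1 `Nc1scc(-c2cccc(C(F)(F)F)c2)c1C(=O)c1ccccc1` gives 83%
compound 2 `Nc1scc(-c2cccc([N+](=O)[O-])c2)c1C(=O)c1ccccc1` gives 47%

Compound 1 stands as the higher of these two numbers. Within the data shown here, the only measured step, a number 36 percentage points lower from compound 1 to compound 2 (beyond the scatter), comes from a nitro in place of trifluoromethyl on an aromatic carbon. Compound 3 `Nc1scc(-c2cccc(C(F)(F)F)c2)c1C(=O)c1ccc(Cl)cc1` has not yet been measured; it differs from compound 1 by chloro in place of hydrogen on an aromatic carbon, a change at a different place, read one bond further out as phenyl to 4-chlorophenyl. Among the measured compounds shown here, no measured step touches this change, so the one step measured does not bear on it directly. For compound 3 a step of none beyond the scatter is expected in this assay, a number 3 percentage points lower from compound 1 to compound 3 (within the scatter). Compound 3 is therefore estimated at 80%, with a range from 60% to 95%.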

Compound 3, a percentage reported as activity, at one concentration (the size of the read-out at that concentration, not a potency): 64%
Compound 3: the middle estimate sits 16 percentage points above what was measured; the measured number falls inside the stated range.
By their numbers in this assay, from the lowest: compound 2; then compound 3; then compound 1.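

In this assay, the change from phenyl to 4-chlorophenyl gives a number 19 percentage points lower from compound 1 to compound 3 (beyond the scatter). Among these compounds, the earlier step concerned only the other aromatic ring, so this result is the first to show that the read-out also responds to a change on this ring, even one as small as a single chloro. Nothing available explains why the number falls. Going by these compounds, whether fluoro, methoxy or an amine at this same place would lower the number as well remains open, as does whether chloro would have a similar effect on compound 2.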